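The compounds below may be only part of what the source reports. "The series", "measured", "known", "first", "only" and "open" are said of these compounds alone.

Measured in a functional assay on U2OS cells (Homo sapiens) for inhibition, read by colorimetric assay, with a stated time of 3 days; on this read-out lower numbers stand for stronger inhibition and higher numbers for weaker inhibition:
- compound 1 `COc1ccc2sc(NC(=O)CCCCCCNC(=O)C(O)(O)C(F)(F)F)nc2c1`: 3290 nM
- compound 2 `O=C(CCCCCCNC(=O)C(O)(O)C(F)(F)F)Nc1ncc(-c2ccc(O)cc2)s1`: 740 nM

Compound 1 stands highest of the two at 3290 nM, the weaker inhibitor on this read-out. Compound 2 gives the lower number, 740 nM, and the gap between the two lies beyond the scatter. For the measured compounds named here, with only these two values, no measured step isolates a single structural change.

Compound 3 `O=C(CCCCCCNC(=O)C(O)(O)C(F)(F)F)Nc1nc2ccccc2s1` has not yet been measured. Its difference from compound 1 is hydrogen in place of methoxy on an aromatic carbon. The rest of the structure stays as in compound 1. Going by the values given here, the data hold no measured example of this change, so any expectation for this assay is weakly grounded. The expected outcome is no step beyond the scatter, with no firm direction, and the number should stay close to that of compound 1. The estimated step is a 1.3-fold lower number from compound 1 to compound 3 (0.12 log units; within the scatter). For compound 3 the expected value is 2500 nM, with an estimated range from 1000 nM to 6500 nM.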

Compound 3, half-maximal inhibitory concentration: 1410 nM
Beside the measured number, compound 3's estimate is 1.8-fold (0.25 log units) above it; the range from low to high includes it.
By their numbers in this assay, from the lowest: compounds 2 and 3 (each within the scatter of the next); then compound 1.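

In this assay, for the compounds shown here, hydrogen in place of methoxy on this aromatic carbon, meta to a fused ring and para to a fused ring, gives a 2.3-fold lower number from compound 1 to compound 3 (0.37 log units; beyond the scatter), the first measured step that isolates a single change, and a modest one. The methoxy at this position is therefore not required for inhibition on this read-out: compound 3, which lacks it, gives 1410 nM, and here the group's removal goes with a lower number rather than a loss of activity. No measurement at hand bears on why the number moves in this direction.

This single pair gives one comparison at one position, so it does not show whether the lower number follows from losing the methoxy specifically or would also appear with other replacements, such as an amine or a chlorine atom on the same aromatic carbon. Going by these compounds, whether the step keeps its size with a longer chain in place of the present one also remains open.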